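The compounds below may be only part of what the source reports. "The series", "measured", "known", "first", "only" and "open" are said of these compounds alone.

Compound 1 `NCCCOc1ccc([C@H]2CC[C@]3(CC2)OOC2(O3)C3CC4CC(C3)CC2C4)cc1` is examined in an ADME assay on microsomes from liver (Homo sapiens) for metabolic stability, read by LC-MS, tested at 1 uM; on this read-out higher numbers stand for fast clearance and lower numbers for slow clearance. Its result is a limit of the assay rather than a number: compound 1 gives < 7 mL.min-1.g-1. Compound 2 `NCCOc1ccc([C@H]2CC[C@]3(CC2)OOC2(O3)C3CC4CC(C3)CC2C4)cc1` likewise returns only a limit, < 7 mL.min-1.g-1, so the step that the two limits leave unreadable from compound 1 to compound 2 cannot be sized. Compound 3 `CS(=O)(=O)N1CCN(CCCOc2ccc([C@H]3CC[C@]4(CC3)OOC3(O4)C4CC5CC(C4)CC3C5)cc2)CC1` does give a number in this assay, 68 mL.min-1.g-1, and the steps of an at least 9.7-fold higher number from compound 1 to compound 3 (0.98 log units; beyond the scatter) and an at least 9.7-fold higher number from compound 2 to compound 3 (0.98 log units; beyond the scatter) show that replacing a free amine at the chain end with a 4-(methylsulfonyl)piperazin-1-yl group moves the reading well beyond the scatter toward fast clearance. The two compounds with a free amine both sit at the limit of < 7 mL.min-1.g-1 in this assay, at which 2 of the 3 values shown sit.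

Compound 4 `c1cc([C@H]2CC[C@]3(CC2)OOC2(O3)C3CC4CC(C3)CC2C4)ccc1OCC1CCNCC1` is not yet measured. It differs from compound 1 as follows: piperidin-4-yl in place of 2-aminoethyl on a saturated chain carbon bound to an oxygen on an aromatic ring. The amine remains, now as part of a six-membered ring, and nothing like the sulfonylated piperazine of compound 3 enters. For the measured compounds named here, the only step that bears on the change is the one where the amine was lost, so the expectation for compound 4 is that it behaves like compound 1 and compound 2, with a step of about an at least 1.1-fold higher number from compound 1 to compound 4 (0.05 log units; that floor lies within the scatter). Compound 4 is therefore estimated at 8 mL.min-1.g-1, with a plausible range from 4 mL.min-1.g-1 to 20 mL.min-1.g-1 in this assay.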

Compound 4, intrinsic clearance in microsomes: < 7 mL.min-1.g-1
Compound 4: a limit, no number; the forecaster's own chance of this, stated with the estimate: 55%; middle value at least 1.1-fold (0.05 log units) from the limit.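

In this assay compound 4 also returns a limit rather than a number, so this position now tolerates a (piperidin-4-yl)methoxy group, with its nitrogen held in a six-membered non-aromatic ring, as well as the open 3-aminopropoxy chain of compound 1 without leaving the low end of the read-out. For the compounds shown here, the steps among compounds 1, 2 and 4 cannot be read, as all three are limits, so no order can be given among them, while the one readable step, an at least 9.7-fold lower number from compound 3 to compound 4 (0.98 log units; beyond the scatter), places the ring amine clearly apart from the sulfonylated piperazine. Open-chain and ring amines therefore group together among the compounds shown, with compound 3 the only one going against this pattern: the limit of < 7 mL.min-1.g-1 in this assay, at which 3 of the 4 values shown sit.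

How far compounds 1, 2 and 4 truly differ stays hidden behind that limit. Going by these compounds, compound 3 also carries both a piperazine ring and a methylsulfonyl group, so it remains open which of the two goes with its higher number, and a plain piperazine, or a piperidine with methylsulfonyl on its nitrogen, would be needed to separate them.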